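One Stereocentre Inverted: From Compound 3 to Compound 4

A few compounds are considered here, and "the series" means these few. Any claim that something is new, unique, unknown or untested is made for them only; others in the source may bear on it.

compound 1 `CC(=O)CC/C=C(\C)CCC1=C(C)CCCC1(C)C` — > 15000 nM
compound 2 `C=C1CCCC(C)(C)C1CC[C@]1(C)CC[C@@H]([C@@H](C)C(=O)O)OO1` — > 10000 nM
compound 3 `C=C1CCC[C@H]2[C@](C)(CC[C@]3(C)CC[C@@H]([C@@H](C)C(=O)O)OO3)[C@@H](C)CC[C@]12C` — 820 nM

All three compounds were tested in a functional assay on SF-295 cells (Homo sapiens) for inhibition; a lower number here means a stronger inhibitor of growth, a higher number a weaker inhibitor of growth. For compound 1 the figure > 15000 nM is a limit of the assay and not a number (the limit of > 15000 nM in this assay, at which 1 of the 3 values shown sits). For compound 2 the figure > 10000 nM is likewise a limit of the assay (the limit of > 10000 nM in this assay, at which 1 of the 3 values shown sits). Compound 3 is the only one of the three with a measured number, 820 nM, and it is therefore the sole point of reference for the step that follows. Going by the values given here, no pair of measured compounds differs in just one place, so no measured step is available to calibrate what a change of this kind does here.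

Among the compounds with values here, compound 4 `C=C1CCC[C@H]2[C@](C)(CC[C@]3(C)CC[C@H]([C@@H](C)C(=O)O)OO3)[C@@H](C)CC[C@]12C` has not yet been measured. the two compounds have the same atoms and bonds and differ only in configuration as drawn: 1 of 7 stereo elements differ; a stereocentre at a saturated ring carbon is drawn S in compound 3 and R in compound 4 Since the two compounds share every atom and bond, the change is confined to that one stereocentre, and there is no measured precedent for how much the growth inhibition responds to it. In this assay a modest step toward weaker inhibition is expected, though it may well fall within the scatter. The expected step is a 2.0-fold higher number from compound 3 to compound 4 (0.29 log units; within the scatter). Compound 4 is therefore estimated at 1600 nM, within a range from 400 nM to 6500 nM.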

Compound 4, concentration for 50% growth inhibition: 1460 nM
For compound 4 the middle estimate is 1.1-fold (0.04 log units) above the measured one; low and high end bracket the measured number.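

In this assay, going by these compounds alone, inverting the stereocentre at the saturated ring carbon gives the first measured step, a 1.8-fold higher number from compound 3 to compound 4 (0.25 log units; within the scatter). The earlier compounds shown here offered no pair differing in one place, so this step is the only measure of what a change of this kind does here. It shows that, at this position, the compound drawn R and the compound drawn S cannot be told apart in growth inhibition, since the step lies within the usual scatter of repeated measurements, and the comparison concerns this one centre alone: the fact that compounds 3 and 4 differ only in the configuration as drawn.

On these data alone, whether the same holds for the other stereo elements remains open, since this is a single inversion read in a single assay. Also open, as far as these compounds go, is how a methyl ester or an amide in place of the carboxylic acid would behave with this stereocentre drawn either way, and whether such a replacement would make the configuration at this position matter more than it does in compound 3 and compound 4.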